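A few compounds are considered here, and "the series" means these few. Any claim that something is new, unique, unknown or untested is made for them only; others in the source may bear on it.

Measured so far in an assay on CHO cells for displacement of a labelled ligand from Alpha-1A adrenergic receptor (Homo sapiens), with a stated time of 30 min; on this read-out higher numbers stand for weaker inhibition and lower numbers for stronger inhibition:
compound 1 `COc1cc2nc(N3CCC[C@@H](NC(=O)c4ccco4)C3)nc(N)c2cc1OC` gives 110 nM
compound 2 `COc1cc2nc(N3CCC[C@@H](N)C3)nc(N)c2cc1OC` gives > 1000 nM, a limit of the assay rather than a number
compound 3 `COc1cc2nc(N3CCC[C@H](NC4=CC(=O)c5ccccc5C4=O)C3)nc(N)c2cc1OC` gives 7.08 nM

Of the two numbers, compound 1 is the higher one, compound 3 the lower; compound 2 sits at the limit of > 1000 nM in this assay, at which 1 of the 3 values shown sits.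

Compound 4 `COc1cc2nc(N3CCC[C@H](NC(=O)c4ccco4)C3)nc(N)c2cc1OC` is the next case: the two compounds have the same atoms and bonds and differ only in configuration as drawn: 1 of 1 stereo elements differ; a stereocentre at a saturated ring carbon is drawn R in compound 1 and S in compound 4. Within the data shown here, the only measured step, an at least 9.0-fold higher number from compound 1 to compound 2 (0.95 log units; beyond the scatter), concerns the group on the amine nitrogen and says nothing about configuration. Compound 3 carries the other configuration as drawn but also a different group on the amine nitrogen, so its value shows only what that combination gives. Among the measured compounds shown here, no measured step therefore fixes the direction here. The expectation for compound 4 is a step of a 1.1-fold higher number from compound 1 to compound 4 (0.04 log units; within the scatter), with wide bounds. Compound 4 is estimated at 120 nM, between 20 nM and 800 nM.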

Compound 4, inhibition constant: 0.631 nM
The estimate for compound 4 lay 190-fold (2.28 log units) above the measured number; measured number outside the range, below it.
By their numbers in this assay, from the lowest: compound 4; then compound 3; then compound 1. At a limit, above all of these: compound 2.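

In this assay, inverting the one stereocentre at the saturated ring carbon, from R to S, gives a 170-fold lower number from compound 1 to compound 4 (2.24 log units; beyond the scatter). The earlier step concerned only the group on the amine nitrogen; this one shows that configuration at this position also governs the read-out, and strongly. With (furan-2-yl)carbonyl unchanged, the step belongs to the stereocentre alone: the fact that compounds 1 and 4 differ only in the configuration as drawn

Open is whether configuration weighs as heavily with the other groups on the amine nitrogen shown here. Also open, going by these compounds, is how a benzoyl or acetyl group on that nitrogen would read in the S configuration.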